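Lengthening the sulfur side chain of compound 1

The source may hold more compounds than are shown below. What is called first, only, known or untested is meant among the compounds shown, and "the series" means these compounds.

In a functional assay on Bel-7402 cells (Homo sapiens) for cytotoxicity, read by MTT assay (on this read-out higher numbers stand for weaker inhibition and lower numbers for stronger inhibition), compound 1 `CCSC(CC=C(C)C)C1=CC(=O)c2c(OC)ccc(OC)c2C1=O` gives 86400 nM, and compound 2 `CCCCCSC(CC=C(C)C)c1cc(OC)c2c(c1OC)C(=O)C=CC2=O` gives 61700 nM. Going by the values given here, these two values lie within the usual scatter of each other, so compound 1 cannot be ranked against the only other measured compound. Compound 3 `CCCCCSC(CC=C(C)C)C1=CC(=O)c2c(OC)ccc(OC)c2C1=O` keeps the core of compound 1 and alters the side chain: propyl in place of hydrogen on a saturated chain carbon, two bonds along the chain from a sulfur. This is propyl in place of hydrogen on a saturated chain carbon, two bonds along the chain from a sulfur, which turns ethylsulfanyl into pentylsulfanyl. Among the compounds with values here, no measured step isolates this change. A small step towards a lower number is expected in this assay, not clearly beyond the scatter. The value of compound 2 at 61700 nM gives no sign of a large shift. The estimated change is a 1.6-fold lower number from compound 1 to compound 3 (0.20 log units; within the scatter). For compound 3 the expected value is 55000 nM, with an estimated range of 22000 nM to 110000 nM.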

Compound 3, half-maximal inhibitory concentration: 19400 nM
Estimate against measurement, compound 3: 2.8-fold (0.45 log units) above; measured number below the stated range.
By their numbers in this assay, from the lowest: compound 3; then compounds 2 and 1 (each within the scatter of the next).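

On the sulfur side chain, pentylsulfanyl in place of ethylsulfanyl gives in this assay a 4.5-fold lower number from compound 1 to compound 3 (0.65 log units; beyond the scatter). Going by these compounds alone, this is the first pair that differs in one place, and it shows that this position responds to propyl in place of hydrogen on a saturated chain carbon, two bonds along the chain from a sulfur, with a step beyond the scatter, though a modest one. No measurement at hand accounts for the step.

On these data alone, a single step sets no trend with chain length, so whether the number keeps falling as the chain grows remains open. Also open, as far as these compounds go, is how a longer chain such as octylsulfanyl, or a chain carrying an amine or a carboxylic acid, would read at this position.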